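Sulfonamide Tolerance in HEK293 Cells: From Compound 3 to 4

The compounds below may be only part of what the source reports. "The series", "measured", "known", "first", "only" and "open" are said of these compounds alone.

Three sulfonamides on a shared core have been measured in an ADME assay on HEK293 cells (Homo sapiens) for cytotoxicity, read by resazurin assay, with a stated time of 48 h; a higher number here means that more compound is tolerated, a lower number that less compound is tolerated. Compound 1 `O=S(=O)(Nc1ccc2oc(-c3ccccc3)nc2c1)c1ccccc1C(F)(F)F` gives 80000 nM. Compound 2 `O=S(=O)(Nc1ccc2oc(-c3ccccc3)nc2c1)c1cccc(O)c1` reaches only a limit of the assay, > 100000 nM. Compound 3 `Cc1ccc(S(=O)(=O)Nc2ccc3oc(-c4ccccc4)nc3c2)cc1` gives 75000 nM. Compound 3 therefore holds the lowest of the two numbers recorded, but its nearest neighbour, compound 1, sits within the scatter of it, so the two are not distinguished. Among the compounds with values here, the single measured step, an at least 1.3-fold lower number from compound 2 to compound 3 (0.12 log units; that floor lies within the scatter), leans on a limit, (the limit of > 100000 nM in this assay, at which 1 of the 3 values shown sits), and its floor lies within the scatter.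

Compound 4 `COc1ccccc1S(=O)(=O)Nc1ccc2oc(-c3ccccc3)nc2c1` has not yet been measured. It differs from compound 3 in one place: 2-methoxyphenyl in place of 4-methylphenyl on a sulfonyl sulfur. Within the data shown here, the only measured step, from compound 2 to compound 3, swaps one substituted phenyl for another on the same sulfonyl sulfur and amounts to no more than the scatter; likewise the numbers of compound 1 and compound 3, which differ in their phenyl substituent, lie close together. The step is expected to stay within the scatter, a 1.1-fold higher number from compound 3 to compound 4 (0.05 log units; within the scatter), with a limit remaining possible. Compound 4 is estimated at 85000 nM, ranging from 40000 nM to 160000 nM.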

Compound 4, half-maximal cytotoxic concentration: 41000 nM
Beside the measured number, compound 4's estimate is 2.1-fold (0.32 log units) above it, and the stated range covers the measured number.
By their numbers in this assay, from the lowest: compounds 4, 3 and 1 (each within the scatter of the next). At a limit, above all of these: compound 2.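

In this assay, within the data shown here, the change to 2-methoxyphenyl on a sulfonyl sulfur gives the first step in this set to pass the scatter, an at least 2.4-fold lower number from compound 2 to compound 4 (0.38 log units; beyond the scatter), so the group on this sulfur can separate two compounds on the shared core. Neither of the other two steps separates compounds in this way: a 1.8-fold lower number from compound 3 to compound 4 (0.26 log units; within the scatter), and a 2.0-fold lower number from compound 1 to compound 4 (0.29 log units; within the scatter), so 2-methoxyphenyl cannot be told apart from 4-methylphenyl, nor methoxy from trifluoromethyl on the aromatic carbon. The one step beyond the scatter is only a floor, with compound 2 held at a limit of the assay rather than at a number: the limit of > 100000 nM in this assay, at which 1 of the 4 values shown sits.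

The compounds shown leave open whether the step from 3-hydroxyphenyl to 2-methoxyphenyl depends on the methoxy group itself or on where it stands on the phenyl ring, a question that a 4-methoxyphenyl on the same sulfur would address. They also leave open how far the number in this assay would move with an amine or a carboxylic acid on this phenyl ring, since every substituent shown so far leaves the numbers close together or at the limit.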